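Trading a fluoro-methoxy benzyl group for a hydroxy-methoxy one

This account rests on a few compounds, and the source may have more. Where it says the series, first, only, none or still open, it means among the compounds named here.

In an ADME assay on HepG2 cells (Homo sapiens) for cytotoxicity, read by luminescence, CellTiter-Glo and ATP content, with a stated time of 72 h (a higher number here means that more compound is needed for the effect, a lower number that less compound is needed), compound 2 `COc1ccc(F)cc1CNCCCNc1ccnc2cc(Oc3ccc(C(C)(C)C)cc3)ccc12` gives 7200 nM. For the measured compounds named here, of the two numbers recorded so far this is the top one, but the only comparison, compound 1 `COc1cccc(Oc2ccc3c(NCCCNCc4cccc(OC)c4O)ccnc3c2)c1` at 5300 nM, sits so close that the gap is within the ordinary scatter of the method, so nothing separates the two on this evidence.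

Going by the values given here, compound 3 `COc1cccc(CNCCCNc2ccnc3cc(Oc4ccc(C(C)(C)C)cc4)ccc23)c1O` keeps the core and the aryl ether of compound 2 and changes only the benzyl group: 2-hydroxy-3-methoxyphenyl in place of 5-fluoro-2-methoxyphenyl on a saturated chain carbon bound to an amine nitrogen The new group is the one already carried by compound 1, while the aryl ether remains that of compound 2.

Among the compounds with values here, no step between measured compounds is available to anchor this change. Compound 1 and compound 2 both land in the same region of this assay, so compound 3 is expected to stay there too, with a step of a 1.2-fold lower number from compound 2 to compound 3 (0.08 log units; within the scatter) that is not expected to exceed the scatter. For compound 3 the estimate in this assay is 6000 nM, with a range from 2500 nM to 14000 nM.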

Compound 3, half-maximal effective concentration: 1500 nM
The estimate for compound 3 lay 4.0-fold (0.60 log units) above the measured number; the measured number lies below the stated range.
By their numbers in this assay, from the lowest: compound 3; then compounds 1 and 2 (each within the scatter of the next).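

In this assay the benzyl group on the chain amine proves able to move the number: 2-hydroxy-3-methoxyphenyl in place of 5-fluoro-2-methoxyphenyl gives a step beyond the scatter (a 4.8-fold lower number from compound 2 to compound 3 (0.68 log units; beyond the scatter)). With that benzyl group held fixed, the aryl ether also counts, as 4-(tert-butyl)phenyl in place of 3-methoxyphenyl on an oxygen on an aromatic ring gives a second such step (a 3.5-fold lower number from compound 1 to compound 3 (0.55 log units; beyond the scatter)). Nothing measured here offers an explanation for either step.

The compounds shown do not separate the loss of the fluorine from the gain of the hydroxy group or the placing of the methoxy group, since all of these change together. Also open, as far as these compounds go, is how this assay would respond to a longer chain between the two amine nitrogens, or to a carboxylic acid on the benzyl ring.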